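Swapping the amide amine on a thiazolidinedione core

The source may hold more compounds than are shown below. What is called first, only, known or untested is meant among the compounds shown, and "the series" means these compounds.

The series shares the core seen in compound 1 `Cn1c(/C=C2\SC(=O)N(CC(=O)Nc3cc(C(C)(C)C)on3)C2=O)nc2ccccc21` and is followed in a functional assay on A549 cells (Homo sapiens) for inhibition, read by MTT assay, with a stated time of 48 h; a higher number here means a weaker inhibitor, a lower number a stronger inhibitor. In this assay compound 1 gives 15300 nM, the lowest of the two numbers reported, with compound 3 `CC(C)n1c(/C=C2\SC(=O)N(CC(=O)N3CCCCC3)C2=O)nc2ccccc21` giving 28200 nM, a gap that lies within the scatter. Compound 2 `CC(C)n1c(/C=C2\SC(=O)N(CC(=O)N3CCCC3)C2=O)nc2ccccc21` gives only a limit in this assay, > 50000 nM. Going by the values given here, the one measured step that touches the amide substituent, an at least 1.7-fold lower number from compound 2 to compound 3 (0.24 log units; that floor lies within the scatter), is bounded by the limit of > 50000 nM in this assay, at which 1 of the 3 values shown sits, and so tells little beyond the scatter.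

Compound 4 `Cn1c(/C=C2\SC(=O)N(CC(=O)N3CCOCC3)C2=O)nc2ccccc21` differs from compound 1 by morpholin-4-yl in place of (5-(tert-butyl)-1,2-oxazol-3-yl)amino on a carbonyl carbon. No measured pair exchanges an aryl-amino amide for a cyclic amine amide, so only the cyclic-amine pair of compound 2 and compound 3 bears on it, and both of those sit at or near the weak end of the numbers shown. Compound 4 is therefore expected to give a somewhat higher number than compound 1, a step of a 2.0-fold higher number from compound 1 to compound 4 (0.29 log units; within the scatter) that may not exceed the scatter. The estimate for compound 4 in this assay is 30000 nM, with a range from 12000 nM to 80000 nM.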

Compound 4, half-maximal inhibitory concentration: 38500 nM
The estimate for compound 4 lay 1.3-fold (0.11 log units) below the measured number; measured number inside the range.
By their numbers in this assay, from the lowest: compounds 1, 3 and 4 (each within the scatter of the next, the first and the last beyond it). At a limit, above all of these: compound 2.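

On the carbonyl carbon of the shared core, morpholin-4-yl in place of (5-(tert-butyl)-1,2-oxazol-3-yl)amino gives a 2.5-fold higher number from compound 1 to compound 4 (0.40 log units; beyond the scatter) in this assay, the only step shown that joins two exact numbers and lies beyond the scatter. The earlier pair of compound 2 and compound 3 only exchanged one cyclic amine for another and was bounded by a limit, so it could not show that an aryl-amino amide and a cyclic amine amide can be told apart in this read-out. The exchange takes out a five-membered aromatic ring and 1 hydrogen-bond donor and brings in a six-membered non-aromatic ring with 0 hydrogen-bond donors, and no measurement shown ties the step to any one of these differences.

As far as these compounds go, whether the step follows the amide hydrogen or the aromatic ring stays open, and a methyl group on that amide nitrogen or a plain phenylamino group in the same place would separate the two. From the compounds shown here alone, how a piperazin-1-yl group on that carbonyl carbon would read also remains open.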